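Replacing a sulfamoylphenyl group with a methylpyridinyl group

The source may hold more compounds than are shown below. What is called first, only, known or untested is meant among the compounds shown, and "the series" means these compounds.

Compound 1 `O=C(O)Cc1sc(C(c2ccc(F)cc2)c2ccc(F)cc2)nc1-c1ccco1` gives 140 nM in an in vitro functional assay on HEK285-7 cells for antagonist activity at prostaglandin D2 receptor 2 (Homo sapiens), read by BRET and beta-arrestin recruitment; on this read-out lower numbers stand for stronger inhibition and higher numbers for weaker inhibition.
Compound 2 `O=C(O)Cc1sc(C(c2ccc(F)cc2)c2ccc(F)cc2)nc1-c1ccnc(N2CCCC2)c1` gives > 100000 nM in this assay, which is a limit of the assay and not a number.
Compound 3 `NS(=O)(=O)c1ccc(-c2nc(C(c3ccc(F)cc3)c3ccc(F)cc3)sc2CC(=O)O)cc1` gives > 100000 nM in this assay, again a limit and not a number.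

Compound 3 therefore stands at the weak end of the values shown, at the same limit as compound 2 (the limit of > 100000 nM in this assay, at which 2 of the 3 values shown sit). Compound 4 `Cc1cc(-c2nc(C(c3ccc(F)cc3)c3ccc(F)cc3)sc2CC(=O)O)ccn1` differs from compound 3 in one place: 2-methylpyridin-4-yl in place of 4-sulfamoylphenyl on an aromatic carbon. For the measured compounds named here, two measured steps bear on this change. From the furan of compound 1, both six-membered aromatic replacements gave an at least 710-fold higher number from compound 1 to compound 2 (2.85 log units; beyond the scatter) and an at least 710-fold higher number from compound 1 to compound 3 (2.85 log units; beyond the scatter). The step that the two limits leave unreadable from compound 2 to compound 3 cannot be read, as both values are limits. Compound 4 carries a pyridinyl group like compound 2, so a weak result is expected. For compound 4 the estimated step is an at least 3.3-fold lower number from compound 3 to compound 4 (0.52 log units; beyond the scatter), which starts from a limit and is itself uncertain. Compound 4 is estimated at 30000 nM, within 3000 nM to 100000 nM.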

Compound 4, half-maximal inhibitory concentration: 53 nM
Compound 4: the middle estimate sits 570-fold (2.75 log units) above what was measured; measured number below the stated range.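

The earlier compounds shown here left it possible that no six-membered aromatic ring could replace furan-2-yl at this position, but 2-methylpyridin-4-yl does so with no loss in this assay, giving a 2.6-fold lower number from compound 1 to compound 4 (0.42 log units; beyond the scatter). The group on the pyridinyl ring also matters greatly, as methyl in place of pyrrolidin-1-yl gives an at least 1800-fold lower number from compound 2 to compound 4 (3.27 log units; beyond the scatter), while the swap from 4-sulfamoylphenyl gives an at least 1800-fold lower number from compound 3 to compound 4 (3.27 log units; beyond the scatter). Both of these steps start from limits of the assay and not from numbers, so their full size stays unknown: the limit of > 100000 nM in this assay, at which 2 of the 4 values shown sit.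

The compounds shown leave open whether an ethyl group or an amine on the pyridinyl ring would keep this activity. They also leave open how a plain phenyl group or an unsubstituted pyridin-4-yl group would behave at this position.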